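Moving the trifluoromethyl group around the aromatic ring

The source may report more compounds than this note shows. Statements on the series, on what has been measured and on what is new or still open speak of the compounds shown alone.

Measured compounds:
Compound 1 `O=C(c1ccccc1)c1cccc(OCC(O)CN2CCC(N3Cc4ccccc4C3=O)CC2)c1` gives 960 nM in an assay on isolated protein for inhibition of sodium channel protein type 9 subunit alpha (Mus musculus), read by patch clamp; a lower number here means a stronger inhibitor, a higher number a weaker inhibitor.
Compound 2 `O=C1c2ccccc2CN1C1CCN(CC(O)COc2cccc(C(F)(F)F)c2)CC1` gives 790 nM in this assay.

Compound 2 has the lowest of the two numbers shown; the one measured step, a 1.2-fold lower number from compound 1 to compound 2 (0.08 log units; within the scatter), lies within the scatter, so the two cannot be told apart. Compound 3 `O=C1c2ccccc2CN1C1CCN(CC(O)COc2ccc(C(F)(F)F)cc2)CC1` has not been measured. It differs from compound 2 in one place: 4-(trifluoromethyl)phenyl in place of 3-(trifluoromethyl)phenyl on an oxygen on a saturated carbon. Among the measured compounds shown here, the only measured step, a 1.2-fold lower number from compound 1 to compound 2 (0.08 log units; within the scatter), exchanges one group for another at the same position and does not move a group around the ring, so nothing measured bears directly on this change. With no step beyond the scatter anywhere in the set, the expected step is a 1.0-fold higher number from compound 2 to compound 3 (0.01 log units; within the scatter), meaning no change beyond the scatter. Compound 3 is therefore estimated at 800 nM, with a range from 300 nM to 2500 nM.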

Compound 3, half-maximal inhibitory concentration: 100 nM
Compound 3: middle estimate off by 8.0-fold (0.90 log units), on the high side; measured number outside the range, below it.
By their numbers in this assay, from the lowest: compound 3; then compounds 2 and 1 (each within the scatter of the next).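

In this assay, where the trifluoromethyl group sits on the ring clearly matters: with the same atoms joined differently, the step is a 7.9-fold lower number from compound 2 to compound 3 (0.90 log units; beyond the scatter), and it lies beyond the scatter. Compound 1 and compound 2 could not be told apart, so exchanging benzoyl for trifluoromethyl gave no sign that this part of the molecule could shift the number at all. Nothing shown here explains why 4-(trifluoromethyl)phenyl and 3-(trifluoromethyl)phenyl differ on this oxygen.

Going by these compounds, it remains open whether benzoyl would respond to the same move around the ring as trifluoromethyl does. On these data alone, it is also open whether another group in place of the trifluoromethyl of compound 3, at 100 nM, such as a nitrile, a methoxy group or a carboxylic acid, would keep a number this low.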